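The source may report more compounds than this note shows. Statements on the series, on what has been measured and on what is new or still open speak of the compounds shown alone.

Measured compounds in a functional assay on MCF7 cells (Homo sapiens) for inhibition, read by MTT assay; a lower number here means a stronger inhibitor, a higher number a weaker inhibitor:
- compound 1 `COc1cc2ncnc(Nc3ccc(NC(=O)c4cccc(F)c4)cc3)c2cc1OC` gives 13600 nM
- compound 2 `COc1cc2ncnc(Nc3ccc(NC(=O)c4ccc(F)cc4)cc3)c2cc1OC` gives 27000 nM
- compound 3 `COc1cc2ncnc(Nc3ccc(NC(=O)c4cccc(I)c4)cc3)c2cc1OC` gives 30000 nM

All three numbers sit in a narrow, weak band. Compound 2 stands second highest of the three: its neighbour is compound 3, a step within the scatter, and the furthest is compound 1, from which a 2.0-fold higher number from compound 1 to compound 2 (0.30 log units; within the scatter) is also within the scatter. Going by the values given here, the only step read as beyond the scatter is a 2.2-fold higher number from compound 1 to compound 3 (0.34 log units; beyond the scatter), a modest rise on the iodo for fluoro swap; a 1.1-fold higher number from compound 2 to compound 3 (0.05 log units; within the scatter) is again flat.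

The unmeasured compound 4 `COc1cc2ncnc(Nc3ccc(NC(=O)c4cc(F)ccc4Br)cc3)c2cc1OC` differs from compound 2 as 2-bromo-5-fluorophenyl in place of 4-fluorophenyl on a carbonyl carbon. Among the compounds with values here, no measured step introduces a bromo group, so the step has no direct precedent. The closest analogy is the halogen enlargement from compound 1 to compound 3, which moved the number only modestly, and the fluoro position change from compound 1 to compound 2, which stayed within the scatter. The series shows the core tolerating these edits of the benzamide ring with little movement, so no step beyond the scatter is expected in this assay, with a slight lean toward a higher number.

Compound 4 is therefore expected at about 32000 nM in this assay, within 12000 nM to 80000 nM, an expected step of a 1.2-fold higher number from compound 2 to compound 4 (0.07 log units; within the scatter).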

Compound 4, half-maximal inhibitory concentration: 26000 nM
Estimate against measurement, compound 4: 1.2-fold (0.09 log units) above, within the range that was stated.
By their numbers in this assay, from the lowest: compounds 1, 4, 2 and 3 (each within the scatter of the next, the first and the last beyond it).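

In this assay, 2-bromo-5-fluorophenyl in place of 4-fluorophenyl on the carbonyl carbon gives a 1.0-fold lower number from compound 2 to compound 4 (0.02 log units; within the scatter) and so stays within the scatter, which extends the tolerance seen at this position to a bromine-bearing ring with two halogens. Going by these compounds alone, the comparison with the iodo analogue gives a 1.2-fold lower number from compound 3 to compound 4 (0.06 log units; within the scatter) and the comparison with the 3-fluorophenyl analogue gives a 1.9-fold higher number from compound 1 to compound 4 (0.28 log units; within the scatter), so compound 4 lies within the scatter of all three earlier compounds, and the only step beyond the scatter in the set remains a 2.2-fold higher number from compound 1 to compound 3 (0.34 log units; beyond the scatter) as the one exception to this flat picture. No independent data bear on why this change leaves the number flat.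

On these data alone, whether an amine, a hydroxyl or a carboxylic acid on this phenyl ring, or a longer alkyl chain in place of the ring, would give a step beyond the scatter remains open. As far as these compounds go, all four compounds share the same core and the same dimethoxy substitution, so it also remains open whether the numbers would leave this weak band with edits away from the carbonyl side.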